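Carbamoyl in Place of Aminomethyl: Compound 3 Expected

The compounds below may be only part of what the source reports. "The series", "measured", "known", "first", "only" and "open" are said of these compounds alone.

Compound 1 `CCNC(=O)c1noc(-c2cc(C(C)C)c(O)cc2O)c1-c1cc(CN)no1` has the lowest of the two numbers measured in a functional assay on HCT-116 cells (Homo sapiens) for inhibition (on this read-out higher numbers stand for weaker inhibition and lower numbers for stronger inhibition), where compound 1 gives 84 nM. Compound 2 `CCNC(=O)c1noc(-c2cc(C(C)C)c(O)cc2O)c1-c1cc(CN2CCN(C)CC2)no1` gives 340 nM, and the step of a 4.0-fold higher number from compound 1 to compound 2 (0.61 log units; beyond the scatter) accompanies 4-methylpiperazin-1-yl in place of amino on a saturated chain carbon bound to an aromatic carbon. carbamoyl in place of aminomethyl on an aromatic carbon is how compound 3 `CCNC(=O)c1noc(-c2cc(C(C)C)c(O)cc2O)c1-c1cc(C(N)=O)no1` differs from compound 1. Going by the values given here, no measured step covers aminomethyl exchanged for carbamoyl; the one measured step that alters this group points toward weaker inhibition. Compound 3 is therefore expected to show a 2.4-fold higher number from compound 1 to compound 3 (0.38 log units; beyond the scatter), a modest rise, with an estimate of 200 nM and a range from 70 nM to 600 nM.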

Compound 3, half-maximal inhibitory concentration: 79 nM
Estimate against measurement, compound 3: 2.5-fold (0.40 log units) above; the range from low to high includes it.
By their numbers in this assay, from the lowest: compounds 3 and 1 (each within the scatter of the next); then compound 2.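

In this assay the exchange of aminomethyl for carbamoyl gives a 1.1-fold lower number from compound 1 to compound 3 (0.03 log units; within the scatter) and so leaves the reading level, which shows that this position accepts a carbamoyl group as well as an aminomethyl group. Going by these compounds alone, the other step, a 4.3-fold lower number from compound 2 to compound 3 (0.63 log units; beyond the scatter), sets carbamoyl apart from the (4-methylpiperazin-1-yl)methyl group, so only that larger group separates from the other two. Nothing available explains why aminomethyl and carbamoyl read alike. From the compounds shown here alone, whether a carboxylic acid, a nitrile or a longer chain ending in an amine would also match at this position remains open.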